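From bromo to cyano on compound 2

The source may hold more compounds than are shown below. What is called first, only, known or untested is meant among the compounds shown, and "the series" means these compounds.

Compound 1 `N#Cc1c(N)cccc1S(=O)(=O)c1cccc(Cl)c1` gives > 200000 nM in a functional assay on MT4 cells (Homo sapiens) for cytotoxicity (on this read-out lower numbers stand for stronger inhibition and higher numbers for weaker inhibition), as a limit. Compound 2 `N#Cc1c(N)cccc1S(=O)(=O)c1cccc(Br)c1` gives > 200000 nM in this assay as a limit too, so it has no number. Among the compounds with values here, the only evidence on the series is the limit of > 200000 nM in this assay, at which 2 of the 2 values shown sit, and nothing finer. Within the data shown here, the one measured step is a step that the two limits leave unreadable from compound 1 to compound 2 and it offers no size to carry over. Among the measured compounds shown here, compound 3 `N#Cc1cccc(S(=O)(=O)c2cccc(N)c2C#N)c1` departs from compound 2 through cyano in place of bromo on an aromatic carbon as its single change: cyano in place of bromo on an aromatic carbon. No step beyond the scatter is expected in this assay and no direction is favoured. The expected step is a number no higher from compound 2 to compound 3 (the limit leaves the size open) in this estimate. For compound 3 the estimate is 200000 nM as the expected value, with 80000 nM and 300000 nM as the ends of the expected range.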

Compound 3, half-maximal inhibitory concentration: > 200000 nM
Compound 3: only a limit was reported; the forecaster's own chance of this, stated with the estimate: 80%; the middle value sits exactly at the limit.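

Within the data shown here, compound 3 is reported only as a limit, as are compound 1 and compound 2, so no step among the three can be read: the limit of > 200000 nM in this assay, at which 3 of the 3 values shown sit. The compounds shown leave open whether chloro, bromo and cyano differ at all in this assay.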